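Swapping the Aryl Group on the Hydrazone Carbon

A few compounds are considered here, and "the series" means these few. Any claim that something is new, unique, unknown or untested is made for them only; others in the source may bear on it.

Compound 1, `CN(C)CCn1cnnc1-c1cc(Oc2ccc(NC(=O)N/N=C/c3cc(Br)c(O)c(Br)c3)cc2F)ccn1`: 4320 nM
Compound 2, `CN(C)CCn1cnnc1-c1cc(Oc2ccc(NC(=O)N/N=C/c3ccc(F)cc3F)cc2F)ccn1`: 810 nM

Both were tested in a functional assay on MKN-45 cells (Homo sapiens) for cytotoxicity, read by MTT assay, with a stated time of 72 h; a higher number here means a weaker inhibitor, a lower number a stronger inhibitor. For the measured compounds named here, compound 1 stands highest of the two numbers, making it the weaker inhibitor; the single measured step, a 5.3-fold lower number from compound 1 to compound 2 (0.73 log units; beyond the scatter), shows that exchanging the group on the carbon with a double bond to nitrogen can lower the number clearly. Compound 3, `CN(C)CCn1cnnc1-c1cc(Oc2ccc(NC(=O)N/N=C/c3ccc(O)cc3O)cc2F)ccn1`, differs from compound 1 as follows: 2,4-dihydroxyphenyl in place of 3,5-dibromo-4-hydroxyphenyl on a carbon with a double bond to nitrogen. That earlier step bears on this change only loosely, since a different group enters. A modest lowering is therefore expected, a 1.7-fold lower number from compound 1 to compound 3 (0.24 log units; within the scatter), giving an estimate for compound 3 of 2500 nM, with a range from 800 nM to 8000 nM.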

Compound 3, half-maximal inhibitory concentration: 2860 nM
For compound 3 the middle estimate is 1.1-fold (0.06 log units) below the measured one, within the range that was stated.
By their numbers in this assay, from the lowest: compound 2; then compounds 3 and 1 (each within the scatter of the next).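

Measured in this assay, the 2,4-dihydroxyphenyl group cannot be told apart from 3,5-dibromo-4-hydroxyphenyl (a 1.5-fold lower number from compound 1 to compound 3 (0.18 log units; within the scatter)). Against 2,4-difluorophenyl, the same group gives a clearly higher number (a 3.5-fold higher number from compound 2 to compound 3 (0.55 log units; beyond the scatter)), so among these three groups on the carbon with a double bond to nitrogen, only 2,4-difluorophenyl stands apart. Nothing available gives a reason for this difference. From the compounds shown here alone, it remains open whether a phenyl ring with a single fluorine, or one carrying an amine or a carboxylic acid, would fall with compound 2 or with compounds 1 and 3.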